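This account rests on a few compounds, and the source may have more. Where it says the series, first, only, none or still open, it means among the compounds named here.

Measured compounds:
- compound 1, `CCCCCCCCCCCCCCC(CO)NC(=O)CCCC(=O)OC`: in an ADME assay on cells (Splenocyte, Mus musculus, strain BALB/c) for cytotoxicity, read by MTT assay, tested at 1 ug/mL (a lower number here means a weaker effect, a higher number a stronger effect of the compound at the concentration tested), compound 1 gives "not determined" (no result reported)
- compound 2, `CCCCCCCCCCCCCCC(CO)N(CC)CC`: in this assay compound 2 gives 7.5%
- compound 3, `CCCCCCCCCCCCCCC(CO)NCCCC`: in this assay compound 3 gives "not determined" (no result reported)

For the measured compounds named here, compound 3 therefore stands without a single number in this assay, and compound 1 is a further entry without one; the only number in this set belongs to compound 2, which shows a weak effect at the concentration tested. Going by the values given here, no step between measured compounds is available, so nothing in the data tells how a change on the amine side of the shared core moves the read-out.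

Compound 4, `CCCCCCCCCCCCCCC(CO)NCCCCCCCCCC`, differs from compound 3 by hexyl in place of hydrogen on a saturated chain carbon, four bonds along the chain from an amine nitrogen. Among the compounds with values here, with no comparable step in hand, the writer expects at most a small shift in this assay, toward a slightly stronger effect if any, and more likely nothing beyond the usual scatter of this assay. On that basis compound 4 is estimated to give 12% in this assay, with an expected range from 2% to 35%.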

Compound 4, a percentage reported as activity, at one concentration (the size of the read-out at that concentration, not a potency): 6.6%
The estimate for compound 4 lay 5.4 percentage points above the measured number; the range from low to high includes it.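

In this assay, for the compounds shown here, compound 3 gives "not determined" (no result reported) while compound 4 gives 6.6% and so no step between the two can be read. Nothing at hand bears on this result. The compounds shown leave open how hexyl in place of hydrogen on this chain moves the read-out.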